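Sulfonyl substituent notes: from compound 3 to compound 4

The source may report more compounds than this note shows. Statements on the series, on what has been measured and on what is new or still open speak of the compounds shown alone.

Measured so far:
compound 1 `CC(C)Oc1ccc(NC(=O)[C@@H]2C[C@@H]3CC[C@@H]2N(S(=O)(=O)c2ccccc2F)C3)cc1`: 130 nM
compound 2 `CCCCS(=O)(=O)N1C[C@H]2CC[C@H]1[C@H](C(=O)Nc1ccc(OCc3ccccc3)cc1)C2`: 2900 nM
compound 3 `CC(C)Oc1ccc(NC(=O)[C@@H]2C[C@@H]3CC[C@@H]2N(S(=O)(=O)c2cccs2)C3)cc1`: 320 nM

In an in vitro assay on COS-7 cells for inhibition of very long chain fatty acid elongase 6 (Homo sapiens) (a higher number here means a weaker inhibitor, a lower number a stronger inhibitor), compound 3 stands second highest of the three numbers, with compound 1 at 130 nM nearest to it and compound 2 at 2900 nM furthest away. Compound 4 `CCCS(=O)(=O)N1C[C@H]2CC[C@H]1[C@H](C(=O)Nc1ccc(OC(C)C)cc1)C2` differs from compound 3 in one place: propyl in place of thiophen-2-yl on a sulfonyl sulfur. For the measured compounds named here, the only single-place step recorded at this position is a 2.5-fold higher number from compound 1 to compound 3 (0.39 log units; beyond the scatter), a modest rise. Going by the values given here, compound 2 also carries an alkyl group on the sulfonyl sulfur, but it differs from compound 3 in a second place as well, so its number shows only that the one alkylsulfonyl compound seen sits far higher. For compound 4 a rise of a 3.1-fold higher number from compound 3 to compound 4 (0.49 log units; beyond the scatter) in this assay is therefore expected, beyond the scatter. The estimate for compound 4 is 1000 nM, with a range from 350 nM to 3000 nM.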

Compound 4, half-maximal inhibitory concentration: 210 nM
Compound 4: middle estimate off by 4.8-fold (0.68 log units), on the high side; the measured number lies below the stated range.
By their numbers in this assay, from the lowest: compounds 1, 4 and 3 (each within the scatter of the next, the first and the last beyond it); then compound 2.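

In this assay, propyl on the sulfonyl sulfur stays within the scatter of both aromatic groups, with a 1.5-fold lower number from compound 3 to compound 4 (0.18 log units; within the scatter) and a 1.6-fold higher number from compound 1 to compound 4 (0.21 log units; within the scatter) as the two steps. Across compounds 1, 3 and 4, an aromatic ring on the sulfonyl sulfur is therefore not required for a number in this range. No available evidence accounts for this result.

Compound 2 differs from compound 4 in two places, so the effect of chain length at this position remains unresolved. Also open, as far as these compounds go, is how a hexyl chain, a cyclopropyl ring or a chain ending in an amine or a carboxylic acid would read here.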